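Losing the cyclohexyl ring of compound 2

The source may report more compounds than this note shows. Statements on the series, on what has been measured and on what is new or still open speak of the compounds shown alone.

In an ADME assay on microsomes from liver (Homo sapiens) for metabolic stability (on this read-out higher numbers stand for a more stable compound and lower numbers for a less stable compound), compound 2 `N[C@H]1CC[C@H](N(C[C@H]2Cc3ccccc3CN2)[C@H]2CCCc3cccnc32)CC1` reads 95% and stands highest of the two measured compounds, with compound 1 `C/C(CN(C[C@H]1Cc2ccccc2CN1)[C@H]1CCCc2cccnc21)=C(\F)CN` well behind at 51% on the same scale.

Compound 3 `C/C(=C/CN)CN(C[C@H]1Cc2ccccc2CN1)[C@H]1CCCc2cccnc21` departs from compound 2 in one place, with a group of 6 heavy atoms (5 carbon, 1 nitrogen; no ring) in place of a group of 7 heavy atoms (6 carbon, 1 nitrogen; one six-membered non-aromatic ring of carbon only), on an amine nitrogen as the whole change. The ring of the 4-aminocyclohexyl group is lost, and one double bond outside aromatic rings comes in.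

Within the data shown here, only one measured step bears on this change, namely a number 44 percentage points higher from compound 1 to compound 2 (beyond the scatter) as a large rise beyond the scatter. In that step, too, a group with no ring and the 4-aminocyclohexyl group trade places on an amine nitrogen, so the new change runs broadly the opposite way. Among the measured compounds shown here, no measured step shows this exact group, which leaves the size uncertain. Resting on compound 2 and that step, a large fall in this assay is expected, and the estimated step is a number 43 percentage points lower from compound 2 to compound 3 (beyond the scatter) in size and direction.

For compound 3 the estimated value is 52% with an expected range from 32% to 74% in this assay.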

Compound 3, percent of the compound remaining: 96%
For compound 3 the middle estimate is 44 percentage points below the measured one, and the stated range ends below it.
By their numbers in this assay, from the lowest: compound 1; then compounds 2 and 3 (each within the scatter of the next).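

At this position, on an amine nitrogen, the ring of the 4-aminocyclohexyl group turns out not to be required for a high reading in this assay: the open chain of compound 3 gives a number 1 percentage points higher from compound 2 to compound 3 (within the scatter). Compound 1 and compound 3 both lack a ring. The chain groups themselves separate the two, with a number 45 percentage points higher from compound 1 to compound 3 (beyond the scatter), where a group without fluorine stands in place of a group with fluorine. Nothing at hand accounts for this gap between two ringless chains.

The three compounds do not tell whether the fluorine alone sets compound 1 apart, or whether the way the chain is arranged about its double bond also plays a part. Nor do they show whether a chlorine on that double bond, or a fully saturated 4-aminobutyl chain on the same amine nitrogen, would read like compound 1 or like compound 3 in this assay.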